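Isoxazole series: amide-to-benzyl exchange on the aminopyridine nitrogen

The source may report more compounds than this note shows. Statements on the series, on what has been measured and on what is new or still open speak of the compounds shown alone.

Measured so far:
compound 1 `CC(C)c1onc(-c2c(Cl)cccc2Cl)c1COc1ccc(N(C)C(=O)c2cccc(C(=O)O)c2)c(C(F)(F)F)n1` — 433 nM
compound 2 `Cc1cc(OCc2c(-c3c(Cl)cccc3Cl)noc2C(C)C)nc2ccccc12` — 147 nM
compound 3 `Cc1cc(C(F)(F)F)cc(OCc2c(-c3c(Cl)cccc3Cl)noc2C(C)C)n1` — 225 nM

In an assay on isolated protein for agonist activity at Bile acid receptor (Homo sapiens), read by FRET (a higher number here means that more compound is needed for the effect, a lower number that less compound is needed), compound 1 gives the highest of the three numbers. Compound 3 sits closest to it, within the scatter; compound 2 sits furthest, beyond the scatter. Among the compounds with values here, no pair among the three differs in a single place, so no step between measured compounds is available.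

Compound 4 `CC(C)c1onc(-c2c(Cl)cccc2Cl)c1COc1ccc(N(C)Cc2ccc(OCCO)cc2)c(C(F)(F)F)n1` is the untested member. It differs from compound 1 in one place: 4-(2-hydroxyethoxy)benzyl in place of (3-carboxyphenyl)carbonyl on a nitrogen on an aromatic ring. Within the data shown here, nothing among the measured compounds shows what this exchange does in this assay; compounds 2 and 3 carry quite different ring systems at the ether oxygen and give no direct read on the nitrogen substituent. The expectation is therefore a step of no clear direction, a 1.2-fold higher number from compound 1 to compound 4 (0.06 log units; within the scatter), with a wide band around it. Compound 4 is estimated at 500 nM, in a range from 100 nM to 3000 nM.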

Compound 4, half-maximal effective concentration: 164 nM
Estimate against measurement, compound 4: 3.0-fold (0.48 log units) above; the measured number falls inside the stated range.
By their numbers in this assay, from the lowest: compounds 2, 4, 3 and 1 (each within the scatter of the next, the first and the last beyond it).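

In this assay, within the data shown here, the exchange of (3-carboxyphenyl)carbonyl for 4-(2-hydroxyethoxy)benzyl on a nitrogen on an aromatic ring gives a 2.6-fold lower number from compound 1 to compound 4 (0.42 log units; beyond the scatter) and is the first single-place step. On the shared core, this position therefore accepts a substituent with neither the carbonyl nor the carboxylic acid, and the number does not rise. No measured evidence bears on the origin of this step.

The exchange alters the link to the nitrogen and the group on the aromatic ring together, so the step cannot be divided between them. A 3-carboxybenzyl group would separate the two, while an unsubstituted benzyl or a 4-methoxybenzyl group would test whether the 2-hydroxyethoxy chain contributes at all.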